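The source may report more compounds than this note shows. Statements on the series, on what has been measured and on what is new or still open speak of the compounds shown alone.

Of the compounds shown here, three sharing one core have been measured for agonist activity at the ecdysone receptor in an assay on cells for agonist activity at ecdysone receptor (Bombyx mori), read by a luciferase reporter, with a stated time of 24 h; a higher number here means that more compound is needed for the effect, a lower number that less compound is needed. Compound 1 `Cc1ccc(C(=O)NN(C(=O)c2ccccc2Cl)C(C)(C)C)cc1` gives 18.6 nM in this assay. Compound 2 `COc1ccc(C(=O)NN(C(=O)c2ccccc2Cl)C(C)(C)C)cc1` gives 51.3 nM, and compound 3 `Cc1cccc(C(=O)NN(C(=O)c2ccccc2Cl)C(C)(C)C)c1C` gives 20 nM in this assay. Compound 3 differs from compound 1 in its core by 2,3-dimethylphenyl in place of 4-methylphenyl on a carbonyl carbon, and the step is a 1.1-fold higher number from compound 1 to compound 3 (0.03 log units; within the scatter). The change from compound 1 to compound 2 is methoxy in place of methyl on an aromatic carbon, and it made a step of a 2.8-fold higher number from compound 1 to compound 2 (0.44 log units; beyond the scatter).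

Compound 4 `COc1cccc(C(=O)NN(C(=O)c2ccccc2Cl)C(C)(C)C)c1C` has not yet been measured in this assay. It is related to compound 3 by methoxy in place of methyl on an aromatic carbon, the same kind of change as that from compound 1 to compound 2, though the place differs: in compound 2 the methoxy sits para to a large group, while in compound 4 it sits ortho to a methyl group and meta to a large group. Because the change made a 2.8-fold higher number from compound 1 to compound 2 (0.44 log units; beyond the scatter), a similar weakening is expected here, estimated as a 2.5-fold higher number from compound 3 to compound 4 (0.40 log units; beyond the scatter). Compound 4 is thus expected to give about 50 nM in this assay, most likely between 22 nM and 115 nM.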

Compound 4, half-maximal effective concentration: 15.5 nM
For compound 4 the middle estimate is 3.2-fold (0.51 log units) above the measured one; measured number outside the range, below it.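

Methoxy in place of methyl on an aromatic carbon gave a 1.3-fold lower number from compound 3 to compound 4 (0.11 log units; within the scatter) in this assay, so on this core the change left the number within the usual scatter. Set beside the earlier step, the same change did not carry over with the same size from the core of compound 1 to the core of compound 3: the same change on two cores in this assay, a 2.8-fold higher number (0.44 log units; beyond the scatter) from compound 1 to compound 2 and a 1.3-fold lower number (0.11 log units; within the scatter) from compound 3 to compound 4, 3.6-fold (0.55 log units) apart, beyond the scatter of two such steps. Within the data shown here, this shows that, in this series, the step measured on one core was a poor guide to the step on the other, but with only two pairs, which also differ in the place of the methoxy, it does not show what sets the difference or how the change would behave on any further core.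

The compounds shown leave open whether an ethoxy, a hydroxyl or an amine at the place of the methoxy in compound 4 would give a number close to that of compound 4. They also leave open whether a methoxy at the place of the other methyl of compound 3 would behave like either step.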